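The compounds below may be only part of what the source reports. "The series", "measured", "known", "first", "only" and "open" are said of these compounds alone.

Measured in a functional assay on T47D cells (Homo sapiens) for inhibition, read by CCK-8 assay, with a stated time of 72 h, tested at 10 uM; a higher number here means more inhibition of growth at the concentration tested, a lower number less inhibition of growth:
compound 1 `CN(C)C(=O)c1cc2cnc(Nc3ccc(NC(=O)C4(C(=O)Nc5ccc(Cl)c(C(F)(F)F)c5)CC4)cc3)nc2n1C1CCCC1`: 55.8%
compound 2 `CN(C)C(=O)c1cc2cnc(Nc3ccc(NC(=O)C4(C(=O)Nc5ccc(C(F)(F)F)cc5)CC4)cc3)nc2n1C1CCCC1`: 94.9%

For the measured compounds named here, of these two compounds, compound 2 stands highest in this assay at 94.9%, with compound 1 the only neighbour on the scale. The next analogue, compound 3 `CN(C)C(=O)c1cc2cnc(Nc3ccc(NC(=O)C4(C(=O)Nc5ccccc5)CC4)cc3)nc2n1C1CCCC1`, has not yet been measured. It replaces the trifluoromethyl of compound 2 with hydrogen: hydrogen in place of trifluoromethyl on an aromatic carbon.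

Going by the values given here, only one measured step bears on this change, and only indirectly. This large step, a number 39.1 percentage points higher from compound 1 to compound 2 (beyond the scatter), alters the same ring, but the trifluoromethyl group remains in both compounds. It shows that growth inhibition can respond strongly to changes on this ring, yet it does not reveal the effect of removing the group. Its direction therefore cannot simply be carried over. The high value of compound 2, 94.9%, leaves little room for a rise, so a moderate fall seems the likelier outcome, though with wide uncertainty. The expected change is a number 18.9 percentage points lower from compound 2 to compound 3 (beyond the scatter). For compound 3, the estimated value is 76%, with an expected range from 45% to 97%.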

Compound 3, percent growth inhibition at one concentration: 93.9%
Estimate against measurement, compound 3: 17.9 percentage points below, and the stated range covers the measured number.
By their numbers in this assay, from the lowest: compound 1; then compounds 3 and 2 (each within the scatter of the next).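

In this assay the change from trifluoromethyl to hydrogen gives a number 1 percentage points lower from compound 2 to compound 3 (within the scatter) and so, on this aromatic carbon para to a large group, the two substituents cannot be told apart by this read-out. Growth inhibition at the concentration tested therefore does not depend on the trifluoromethyl group at this place in this pair, which the earlier compounds could not show, as both of them carried such a group. The plain phenyl ring also gives a number 38.1 percentage points higher from compound 1 to compound 3 (beyond the scatter) and thus, among these three compounds, only the 4-chloro-3-(trifluoromethyl)phenyl group of compound 1 stands apart, though no measurement at hand explains this difference.

Which part of the 4-chloro-3-(trifluoromethyl)phenyl group goes with the value of compound 1 stays open, as the compounds shown do not separate the chloro substituent from the trifluoromethyl group at its other place on the ring. Also open, going by these compounds, is how this para position would respond to a substituent of another kind, such as an amine, a carboxylic acid or a longer alkyl chain, and whether compound 2 and compound 3 would still match at lower concentrations.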